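Another Aryl Group on the Shared Core

A few compounds are considered here, and "the series" means these few. Any claim that something is new, unique, unknown or untested is made for them only; others in the source may bear on it.

Four compounds share one core, an amide-linked pyridyl ether tail on a fused bicyclic ring system carrying an aryl group on its aromatic nitrogen. Compound 1 `CNC(=O)c1cc(Oc2ccc(NC(=O)c3cc4cccnc4n(-c4ccc(F)cc4)c3=O)cc2)ccn1` bears a 4-fluorophenyl group; in a functional assay on NCI-H460 cells (Homo sapiens) for antiproliferative activity, read by MTT assay, with a stated time of 72 h (on this read-out lower numbers stand for stronger inhibition and higher numbers for weaker inhibition), compound 1 gives 210 nM. Compound 2 `CNC(=O)c1cc(Oc2ccc(NC(=O)c3cc4cccnc4n(-c4ccc(OC)cc4)c3=O)cc2)ccn1` in this assay gives "not determined" (no result reported). Compound 3 `CNC(=O)c1cc(Oc2ccc(NC(=O)c3cc4cccnc4n(-c4ccc(Br)cc4F)c3=O)cc2)ccn1` in this assay gives "not determined" (no result reported), so compound 3 stands without any number of its own. Compound 4 `CNC(=O)c1cc(Oc2ccc(NC(=O)c3cc4cccnc4n(-c4ccc(C(F)(F)F)cc4Cl)c3=O)cc2)ccn1` differs from compound 3 by 2-chloro-4-(trifluoromethyl)phenyl in place of 4-bromo-2-fluorophenyl on an aromatic nitrogen. Among the compounds with values here, no pair of measured compounds that differ in a single place is available, so the size and direction of this step cannot be anchored; a change within the usual scatter is as plausible as a modest loss. Compound 4 is estimated to give 350 nM, within a range of 70 nM to 1800 nM.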

Compound 4, half-maximal inhibitory concentration: 2110 nM
Compound 4: middle estimate off by 6.0-fold (0.78 log units), on the low side; measured number outside the range, above it.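

In this assay, within the data shown here, the aryl group on the aromatic nitrogen proves sensitive to change: 2-chloro-4-(trifluoromethyl)phenyl in place of 4-fluorophenyl gives a 10-fold higher number from compound 1 to compound 4 (1.00 log units; beyond the scatter) and so weaker inhibition, the first sized step at this position. Steps involving compound 2 or compound 3 cannot be read, as neither has a number. Nothing measured here explains the loss.

Whether the chlorine, the trifluoromethyl or both together account for this step stays open. So does the effect of an amine or a carboxylic acid on this aryl ring.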